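Pyrrolidinyl for cyclohexylamino on two cores

This account rests on a few compounds, and the source may have more. Where it says the series, first, only, none or still open, it means among the compounds named here.

Measured in an assay on cell membranes for binding affinity to Equilibrative nucleoside transporter 1 (Homo sapiens); a lower number here means a stronger inhibitor, a higher number a weaker inhibitor:
compound 1, `OC[C@H]1OC(n2c(NC3CCCCC3)nc3c(SCc4ccccc4)ncnc32)[C@H](O)[C@@H]1O`: 0.94 nM
compound 2, `OC[C@H]1OC(n2c(N3CCCC3)nc3c(SCc4ccccc4)ncnc32)[C@H](O)[C@@H]1O`: 410 nM
compound 3, `O=[N+]([O-])c1ccc(CSc2ncnc3c2nc(NC2CCCCC2)n3Cc2ccccc2)cc1`: 55 nM

The change pyrrolidin-1-yl in place of cyclohexylamino on an aromatic carbon gives a 440-fold higher number from compound 1 to compound 2 (2.64 log units; beyond the scatter). Compound 3 carries a different core from compound 1; the difference between the two cores is not broken down here. Between compound 2 and compound 3 only the two values can be compared: compound 3 has the lower number in this assay, compound 2 the higher.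

Compound 4, `O=[N+]([O-])c1ccc(CSc2ncnc3c2nc(N2CCCC2)n3Cc2ccccc2)cc1`, is the counterpart of compound 3 with pyrrolidin-1-yl in place of cyclohexylamino on an aromatic carbon. The place line differs from the earlier one only in the neighbouring group, a benzyl group in compound 3 against a 3,4-dihydroxy-5-(hydroxymethyl)oxolan-2-yl group in compound 1, so this is the same kind of change rather than the same change. Among the compounds with values here, on the core of compound 1 it was large; a step of comparable direction, a 150-fold higher number from compound 3 to compound 4 (2.16 log units; beyond the scatter), is expected from compound 3 to compound 4 in this assay, resting on the single earlier step of a 440-fold higher number from compound 1 to compound 2 (2.64 log units; beyond the scatter) and with wide uncertainty because the starting value of compound 3 is 55 nM and only one example exists. Compound 4 is estimated at 8000 nM, expected between 1500 nM and 40000 nM.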

Compound 4, inhibition constant: 1520 nM
The estimate for compound 4 lay 5.3-fold (0.72 log units) above the measured number; the measured number falls inside the stated range.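

In this assay, pyrrolidin-1-yl in place of cyclohexylamino raises the number on both cores, and on the core of compound 3 the change gives a 28-fold higher number from compound 3 to compound 4 (1.44 log units; beyond the scatter), so the direction carries over from the core of compound 1. The size does not carry over: the same change on two cores in this assay, a 440-fold higher number (2.64 log units; beyond the scatter) from compound 1 to compound 2 and a 28-fold higher number (1.44 log units; beyond the scatter) from compound 3 to compound 4, 16-fold (1.20 log units) apart, beyond the scatter of two such steps. Two pairs show only that the size of this step depends on the core; the two cores differ both in the neighbouring group, a benzyl group against a 3,4-dihydroxy-5-(hydroxymethyl)oxolan-2-yl group, and in a nitro group present only in compound 3, so neither difference can be tied to the gap between the steps.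

The compounds shown leave open whether the step goes with the ring size or with the hydrogen-bond donor that leaves with cyclohexylamino, a question that cyclopentylamino or piperidin-1-yl on either core would address. Also open, on these data alone, is how the step behaves with the benzyl group at the neighbouring place and no nitro group on the molecule.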